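The source may report more compounds than this note shows. Statements on the series, on what has been measured and on what is new or still open speak of the compounds shown alone.

This study measured a small set of compounds in a functional assay for inhibition, with Homo sapiens as the target; a lower number here means a stronger inhibitor, a higher number a weaker inhibitor. The compounds share one core and differ in two places: the ring that hangs off the core, and a small group on the ring that carries the amine.

The starting point is compound 1, `c1ccc(Nc2nccc(-c3ccco3)n2)cc1`, which in this assay gives 32000 nM. Compound 2, `CCc1cccc(Nc2nccc(-c3ccco3)n2)c1`, differs from it in one spot: ethyl in place of hydrogen on an aromatic carbon. In this assay compound 2 gives 9700 nM, which is a 3.3-fold lower number from compound 1 to compound 2 (0.52 log units; beyond the scatter).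

Compound 3, `c1ccc(Nc2nccc(-c3ccncc3)n2)cc1`, keeps the unsubstituted amine ring of compound 1 but swaps the ring hanging off the core: pyridin-4-yl in place of furan-2-yl on an aromatic carbon. In this assay compound 3 gives 900 nM, which is a 36-fold lower number from compound 1 to compound 3 (1.55 log units; beyond the scatter), and is the lowest number among the three measured compounds.

Compound 4, `CCc1cccc(Nc2nccc(-c3ccncc3)n2)c1`, has not yet been measured. It carries the core of compound 3 and adds the same change that turned compound 1 into compound 2: ethyl in place of hydrogen on an aromatic carbon. The two cores differ as described by pyridin-4-yl in place of furan-2-yl on an aromatic carbon, and the spot where the ethyl enters is described in the same words for both pairs.

The expectation for compound 4 in this assay is a step of about a 3.0-fold lower number from compound 3 to compound 4 (0.48 log units; beyond the scatter), because the same change gave a 3.3-fold lower number from compound 1 to compound 2 (0.52 log units; beyond the scatter). On that basis compound 4 is estimated at 300 nM, with a plausible range from 100 nM to 900 nM.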

Compound 4, half-maximal inhibitory concentration: 10600 nM
Compound 4: the middle estimate sits 35-fold (1.55 log units) below what was measured, outside the stated range (above it).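

In this assay, ethyl in place of hydrogen on the pyridin-4-yl core gives a 12-fold higher number from compound 3 to compound 4 (1.07 log units; beyond the scatter), so the change that lowered the number on the furan-2-yl core raises it here, and its effect did not carry from one core to the other: the same change on two cores in this assay, a 3.3-fold lower number (0.52 log units; beyond the scatter) from compound 1 to compound 2 and a 12-fold higher number (1.07 log units; beyond the scatter) from compound 3 to compound 4, 39-fold (1.59 log units) apart, beyond the scatter of two such steps

The same result can be read from the other direction, since the ring swap that made such a large difference without the ethyl gives a 1.1-fold higher number from compound 2 to compound 4 (0.04 log units; within the scatter), which means compound 2 and compound 4 cannot be told apart in this assay: the same change on two cores in this assay, a 36-fold lower number (1.55 log units; beyond the scatter) from compound 1 to compound 3 and a 1.1-fold higher number (0.04 log units; within the scatter) from compound 2 to compound 4, 39-fold (1.59 log units) apart, beyond the scatter of two such steps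

This shows that in these four compounds the two changes do not act independently, so a step measured on one core is no safe guide to the other, but it does not show why they interact, and one ethyl group on two cores supports no rule for the wider series.

The compounds shown leave open whether a methyl group, a longer chain such as propyl, or a methoxy group on the same aromatic carbon would also raise the number on the pyridin-4-yl core. They also leave open how the ethyl would behave with another ring on the core, such as pyridin-3-yl or thiophen-2-yl.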